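Morpholine amide in place of ethyl ester on two cores

The compounds below may be only part of what the source reports. "The series", "measured", "known", "first", "only" and "open" are said of these compounds alone.

compound 1, `CCOC(=O)/C=C/c1ccncc1-c1ccc2c(cnn2C)c1`: 102 nM
compound 2, `Cn1ncc2cc(-c3cnccc3/C=C/C(=O)N3CCOCC3)ccc21`: 356 nM
compound 3, `CCOC(=O)/C=C/c1ccncc1-c1ccc2c(ccn2C)c1`: 144 nM

All three were measured in an assay on a protein complex for inhibition of CDK8/Cyclin C (Homo sapiens), with a stated time of 1 h; a lower number here means a stronger inhibitor, a higher number a weaker inhibitor. Compound 1 and compound 2 share one core and differ by morpholin-4-yl in place of ethoxy on a carbonyl carbon, which gave a 3.5-fold higher number from compound 1 to compound 2 (0.54 log units; beyond the scatter). Compound 3 carries the same ethoxycarbonyl as compound 1 on a different core; the difference between the two cores is not broken down here. In this assay compound 3 and compound 1 lie within the scatter of each other, while compound 3 and compound 2 differ beyond it.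

Compound 4, `Cn1ccc2cc(-c3cnccc3/C=C/C(=O)N3CCOCC3)ccc21`, applies the same change to the core of compound 3: morpholin-4-yl in place of ethoxy on a carbonyl carbon. The expectation for it rests on compound 1 and compound 2, whose step a 3.5-fold higher number from compound 1 to compound 2 (0.54 log units; beyond the scatter) came from this change. For compound 4 the expected step is a 3.5-fold higher number from compound 3 to compound 4 (0.54 log units; beyond the scatter). Compound 4 is estimated at 500 nM, between 200 nM and 1300 nM.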

Compound 4, half-maximal inhibitory concentration: 247 nM
Estimate against measurement, compound 4: 2.0-fold (0.31 log units) above; the range from low to high includes it.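

In this assay, morpholin-4-yl in place of ethoxy on a carbonyl carbon gave a 1.7-fold higher number from compound 3 to compound 4 (0.23 log units; within the scatter). Set beside the earlier step on the other core, this one does not differ from it: the same change on two cores in this assay, a 3.5-fold higher number (0.54 log units; beyond the scatter) from compound 1 to compound 2 and a 1.7-fold higher number (0.23 log units; within the scatter) from compound 3 to compound 4, 2.0-fold (0.31 log units) apart, within the scatter of two such steps. This gives no sign that the change behaves differently on the two cores, but two pairs, one of them within the scatter, do not show that a step of fixed size carries over to other cores in this series.

The compounds shown leave open whether other groups on this carbonyl carbon, such as piperidin-1-yl, dimethylamino or hydroxy as in the carboxylic acid, would follow the same course on both cores.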